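The source may hold more compounds than are shown below. What is called first, only, known or untested is meant among the compounds shown, and "the series" means these compounds.

Compound 1, with the structure `CCC(=O)c1ccc(OCCCCOc2cc(C(=O)O)ccc2OC)c(C)c1O`, serves as the starting point of this comparison. In an assay on HEK293 cells for positive allosteric modulation of metabotropic glutamate receptor 3 (Rattus norvegicus), read by thallium flux, with a stated time of 2.5 min (a higher number here means a larger maximal response, a lower number a smaller maximal response), compound 1 reaches 62.5%. Compound 2, with the structure `COc1ccc(C(=O)O)cc1OCCCCOc1ccc(C(=O)C(C)C)c(O)c1C`, differs from compound 1 only by methyl in place of hydrogen on a saturated chain carbon bound to a carbonyl carbon and a saturated chain carbon. In this assay compound 2 reaches 59.9%, so that the change amounts to a number 2.6 percentage points lower from compound 1 to compound 2 (within the scatter). The two compounds therefore cannot be told apart on this read-out.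

Compound 3, with the structure `CCC(=O)c1ccc(OCCCCOc2ccc(F)c(C(=O)O)c2)c(C)c1O`, carries a different core; the difference between the core of compound 1 and that of compound 3 is not broken down here. In this assay compound 3 reaches 18.4%, the lowest of the three numbers, and it lies beyond the usual scatter from both compound 1 and compound 2.

Compound 4, with the structure `Cc1c(OCCCCOc2ccc(F)c(C(=O)O)c2)ccc(C(=O)C(C)C)c1O`, has not yet been measured. It differs from compound 3 by methyl in place of hydrogen on a saturated chain carbon bound to a carbonyl carbon and a saturated chain carbon, the same change that leads from compound 1 to compound 2, and at the same kind of place in the same printed words. Since that change produced only a number 2.6 percentage points lower from compound 1 to compound 2 (within the scatter), compound 4 is expected to stay close to compound 3 in this assay, with an estimated a number 1.4 percentage points lower from compound 3 to compound 4 (within the scatter). On this basis compound 4 is estimated to reach 17%, most likely between 8% and 28%, though the expectation rests on a single earlier example of the change, made on a different core.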

Compound 4, largest response reached (reported as percent of maximum), in percent of the reference or control that the assay uses: 31.3%
Beside the measured number, compound 4's estimate is 14.3 percentage points below it, outside the stated range (above it).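

In this assay the change from propanoyl to isopropylcarbonyl, methyl in place of hydrogen on a saturated chain carbon bound to a carbonyl carbon and a saturated chain carbon, gives a number 12.9 percentage points higher from compound 3 to compound 4 (beyond the scatter), so on the core of compound 3 this small change moves the maximal response beyond the usual scatter. For the compounds shown here, the step measured on the core of compound 1 therefore does not carry over unchanged to the core of compound 3, and the size of the change depends on the core that bears it: the same change on two cores in this assay, a number 2.6 percentage points lower (within the scatter) from compound 1 to compound 2 and a number 12.9 percentage points higher (beyond the scatter) from compound 3 to compound 4, 15.5 percentage points apart, beyond the scatter of two such steps This rests on only two pairs, so it shows that the core matters here but neither which part of the core difference is responsible nor how the change would behave on any third core.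

The compounds shown leave open how a longer chain, such as butanoyl, or a branched group such as tert-butyl in place of the isopropyl would read on either core. They also leave open whether the same methyl step would keep its size on a core with chloro in place of fluoro, or with an amide in place of the carboxylic acid.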